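Compound 2 to compound 3: methoxy in place of methyl

A few compounds are considered here, and "the series" means these few. Any claim that something is new, unique, unknown or untested is made for them only; others in the source may bear on it.

Compound 1 `O=C(Nc1ccc2c(c1)B(O)OC2)c1ccccc1Cl` and compound 2 `Cc1ccccc1C(=O)Nc1ccc2c(c1)B(O)OC2` share one core. In a functional assay on PBMC cells (Homo sapiens) for inhibition, read by HTRF, with stated times of 15 min and 24 h (on this read-out lower numbers stand for stronger inhibition and higher numbers for weaker inhibition), compound 1 gives > 100000 nM, which is a limit and not a number. Compound 2 gives > 100000 nM, again a limit and not a number, so it has no measured potency to start from. Both compounds sit at the same ceiling, as the limit of > 100000 nM in this assay, at which 2 of the 2 values shown sit, records. Among the compounds with values here, the one measured step is a step that the two limits leave unreadable from compound 1 to compound 2, with methyl in place of chloro on an aromatic carbon. Compound 3 `COc1ccccc1C(=O)Nc1ccc2c(c1)B(O)OC2` carries methoxy in place of methyl on an aromatic carbon, ortho to a large group: methoxy in place of methyl on an aromatic carbon. Given a step that the two limits leave unreadable from compound 1 to compound 2, no size or direction can be carried over, and the expectation is no step beyond the scatter in this assay. The expected step is a number no higher from compound 2 to compound 3 (the limit leaves the size open). For compound 3 the estimated value is 100000 nM, within an expected range of 30000 nM to 200000 nM.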

Compound 3, half-maximal inhibitory concentration: > 100000 nM
Compound 3 gave a limit, no number (the forecaster's own chance of this, stated with the estimate: 85%); the middle value sits exactly at the limit.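

In this assay compound 3 also gives a limit and not a number, so no new step can be read among compound 1, compound 2 and compound 3: the limit of > 100000 nM in this assay, at which 3 of the 3 values shown sit. The compounds shown leave open what potency any of them has, and which group at this place on the shared core would give a measurable value.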